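The source may hold more compounds than are shown below. What is called first, only, known or untested is meant among the compounds shown, and "the series" means these compounds.

Measured so far:
compound 1, `O=[N+]([O-])c1ccc(-c2ccc3c(O)cccc3c2)cc1`: 15%
compound 2, `N#Cc1ccc(-c2ccc3c(O)cccc3c2)cc1`: 16%

In an assay for binding affinity to 17-beta-hydroxysteroid dehydrogenase type 1 (Homo sapiens), with a stated time of 20 min, tested at 1 uM (on this read-out lower numbers stand for less inhibition and higher numbers for more inhibition at the one concentration tested (going by the name of the read-out)), compound 1 gives 15% and compound 2 gives 16%. Among the measured compounds shown here, the one measured step, a number 1 percentage points higher from compound 1 to compound 2 (within the scatter), is within the scatter, so the two numbers are not distinguishable; compound 2 stands at one end of the two values, with compound 1 within the scatter of it, and no order between them is established.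

Compound 3, `CNS(=O)(=O)c1ccc(-c2ccc3c(O)cccc3c2)cc1`, differs from compound 2 by methylsulfamoyl in place of cyano on an aromatic carbon. For the measured compounds named here, no measured step covers an exchange of cyano for methylsulfamoyl. Going by the values given here, the only step available, nitro to cyano, gave no movement in this assay beyond the scatter, and the series so far sits at low inhibition throughout. The expected step is therefore a number 2 percentage points higher from compound 2 to compound 3 (within the scatter), none beyond the scatter, with a wide range to allow for the untested group. Compound 3 is expected to give 18% in this assay, between 3% and 40%.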

Compound 3, a percentage reported as inhibition, at one concentration (the size of the read-out at that concentration, not a potency): 12%
Compound 3: middle estimate off by 6 percentage points, on the high side; the range from low to high includes it.
By their numbers in this assay, from the lowest: compounds 3, 1 and 2 (each within the scatter of the next).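

In this assay, methylsulfamoyl in place of cyano gives a number 4 percentage points lower from compound 2 to compound 3 (within the scatter) for this change, and methylsulfamoyl in place of nitro gives a number 3 percentage points lower from compound 1 to compound 3 (within the scatter) for the second exchange. The position, on an aromatic carbon para to a large group, therefore now carries a third group, one with more heavy atoms than cyano and with a hydrogen-bond donor, and the read-out still shows no separable difference among the three compounds. Nothing available bears on why these exchanges leave the read-out within the scatter.

Still open, as far as these compounds go, is whether any group at this position can move the read-out beyond the scatter, for example a carboxylic acid, an amine or a longer chain on the sulfamoyl nitrogen. Also open, from the compounds shown here alone, is how a change elsewhere on the shared core, such as at its hydroxyl, would compare.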